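Chloro for fluoro on the triazole aryl: compound 4

The compounds below may be only part of what the source reports. "The series", "measured", "known", "first", "only" and "open" are said of these compounds alone.

Working notes on the sulfonamide series. Compound 1 `Cc1ccc(-n2cc(-c3cccc(NS(=O)(=O)c4c[nH]c(=O)[nH]c4=O)c3)nn2)cc1` carries a 4-methylphenyl on the triazole nitrogen; compound 2 `O=c1[nH]cc(S(=O)(=O)Nc2cccc(-c3cn(-c4ccc(Cl)cc4)nn3)c2)c(=O)[nH]1` carries a 4-chlorophenyl there; compound 3 `O=c1[nH]cc(S(=O)(=O)Nc2ccc(-c3cn(-c4ccccc4F)nn3)cc2)c(=O)[nH]1` carries a 2-fluorophenyl and links the anilide differently. In a functional assay on HepG2 cells (Homo sapiens) for antiproliferative activity, read by MTT assay, with a stated time of 24 h (a higher number here means a weaker inhibitor, a lower number a stronger inhibitor), compound 1 gives only a limit, > 20000 nM. In this assay compound 2 gives 1960 nM, so the change of chloro in place of methyl yields an at least 10-fold lower number from compound 1 to compound 2 (1.00 log units; beyond the scatter). Compound 3 likewise gives only a limit in this assay, > 20000 nM. Compound 3 therefore sits at the ceiling of what is measured, as shown by the limit of > 20000 nM in this assay, at which 2 of the 3 values shown sit. Compound 4 `O=c1[nH]cc(S(=O)(=O)Nc2ccc(-c3cn(-c4ccc(Cl)cc4)nn3)cc2)c(=O)[nH]1` differs from compound 3 by 4-chlorophenyl in place of 2-fluorophenyl on an aromatic nitrogen. Within the data shown here, the single measured step that bears on this, an at least 10-fold lower number from compound 1 to compound 2 (1.00 log units; beyond the scatter), concerned a different pair of groups, and the starting point for compound 4 is itself a limit, so no size can be read from compound 3. Compound 4 is nonetheless expected to reach 8000 nM, within 2000 nM to 30000 nM, since it shares its aryl group with compound 2 at 1960 nM; the estimated step is an at least 2.5-fold lower number from compound 3 to compound 4 (0.39 log units; beyond the scatter).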

Compound 4, half-maximal inhibitory concentration: 1980 nM
Estimate against measurement, compound 4: 4.0-fold (0.61 log units) above, and the stated range ends above it.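

On this aromatic nitrogen, 4-chlorophenyl in place of 2-fluorophenyl brings a second compound off the ceiling in this assay, with an at least 10-fold lower number from compound 3 to compound 4 (1.00 log units; beyond the scatter); the starting point of this step is a limit, so it gives a bound and not a size. Compound 2 gives 1960 nM and compound 4 gives 1980 nM, so in these two compounds the 4-chlorophenyl goes with a measured value whichever way the anilide is linked. Compound 1 and compound 3, which lack the 4-chlorophenyl, remain at the ceiling: the limit of > 20000 nM in this assay, at which 2 of the 4 values shown sit.

The step from compound 3 changes both the halogen and its place on the aryl ring, and the compounds shown do not separate the two; a 2-chlorophenyl or a 4-fluorophenyl would. As far as these compounds go, how an aryl carrying an amine or a carboxylic acid would behave at this nitrogen also remains open.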